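The source may hold more compounds than are shown below. What is called first, only, known or untested is meant among the compounds shown, and "the series" means these compounds.

The compounds share one core. Compound 1, `O=C(NCc1ccccc1)c1cncc(Cl)n1`, stands in an ADME assay on HeLa cells (Homo sapiens) for cytotoxicity, read by microscopy, with a stated time of 6 days (a lower number here means that less compound is tolerated, a higher number that more compound is tolerated), as "not determined" (no result reported), with no result reported. Compound 2 is `CCCCCCCCNc1cncc(C(=O)NCc2ccccc2)n1`. In this assay compound 2 gives > 100000 nM, which is a limit of the assay and not a number. Compound 3, `CCCCNc1nccnc1C(=O)NCc1ccccc1`, is the other measured analogue. In this assay compound 3 gives > 100000 nM, also a limit of the assay rather than a number. Compound 2 therefore sits at the limit of > 100000 nM in this assay, at which 2 of the 3 values shown sit, and no single number exists for any of the three compounds in this assay.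

Compound 4 is `CCCCCCNc1cncc(C(=O)NCc2ccccc2)n1` and has not yet been measured in this assay. It differs from compound 2 as follows: hydrogen in place of ethyl on a saturated chain carbon, six bonds along the chain from a nitrogen on an aromatic ring. Among the compounds with values here, no step between two measured compounds is available here, so the size of this change cannot be read from a neighbouring pair, and compound 2 itself offers only a limit in this assay. The expected step of a number no higher from compound 2 to compound 4 (the limit leaves the size open) is none beyond the usual scatter, since compound 2 shows > 100000 nM in this assay. Compound 4 is expected to give 100000 nM in this assay, within a range from 30000 nM to 100000 nM, most probably reported once more as a limit.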

Compound 4, minimum cytotoxic concentration: > 100000 nM
Compound 4: no number, only a limit (the forecaster's own chance of this, stated with the estimate: 80%); the middle value lies on the limit itself.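

In this assay compound 4 gives a limit of the assay and not a number, as compound 2 does, so no step can be read between these two compounds: the limit of > 100000 nM in this assay, at which 3 of the 4 values shown sit. The compounds shown leave open at which concentration compound 2, compound 3 or compound 4 would become cytotoxic, and so how much removing ethyl from the chain matters.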